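Moving the Hydroxyl One Position Costs Potency

The source may hold more compounds than are shown below. What is called first, only, known or untested is meant among the compounds shown, and "the series" means these compounds.

Measured in a functional assay on T47D cells (Homo sapiens) for inhibition; a lower number here means a stronger inhibitor, a higher number a weaker inhibitor:
compound 1 `Oc1ccc(-c2cc(-c3cccc(F)c3)cc(-c3cccc(O)c3)n2)cc1` gives 3510 nM.
compound 2 `Oc1ccc(-c2cc(-c3cccc(F)c3)cc(-c3ccc(O)cc3)n2)cc1` reaches only the assay limit, > 50000 nM.
compound 3 `Oc1cccc(-c2cc(-c3ccccc3C(F)(F)F)cc(-c3cccc(O)c3)n2)c1` gives 4350 nM.

Compound 2 differs from compound 1 by 4-hydroxyphenyl in place of 3-hydroxyphenyl on an aromatic carbon, and this change made an at least 14-fold higher number from compound 1 to compound 2 (1.15 log units; beyond the scatter). The value for compound 2 is a limit, not a number (the limit of > 50000 nM in this assay, at which 1 of the 3 values shown sits). Compound 3 carries a different core, and the difference between the two cores is not broken down here; its value and that of compound 1 lie within the usual scatter of each other.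

Compound 4 `Oc1ccc(-c2cc(-c3ccccc3C(F)(F)F)cc(-c3cccc(O)c3)n2)cc1` is not yet measured. It differs from compound 3 by 4-hydroxyphenyl in place of 3-hydroxyphenyl on an aromatic carbon. The surroundings of the place differ: in compound 1 the changed group sits meta to a 3-fluorophenyl group and meta to a 4-hydroxyphenyl group, whereas in compound 3 it sits meta to a 2-(trifluoromethyl)phenyl group and meta to a 3-hydroxyphenyl group, so this is the same kind of change, not the same change. A step of about an 11-fold higher number from compound 3 to compound 4 (1.06 log units; beyond the scatter) is expected for compound 4 in this assay, resting on an at least 14-fold higher number from compound 1 to compound 2 (1.15 log units; beyond the scatter). Compound 4 is therefore estimated at 50000 nM, likely between 15000 nM and 200000 nM.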

Compound 4, half-maximal inhibitory concentration: 3210 nM
Estimate against measurement, compound 4: 16-fold (1.19 log units) above; measured number outside the range, below it.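

On the core of compound 3, the same move of the hydroxyl gives a 1.4-fold lower number from compound 3 to compound 4 (0.13 log units; within the scatter), so in this assay the large loss seen on the core of compound 1 does not carry over: the same change on two cores in this assay, an at least 14-fold higher number (1.15 log units; beyond the scatter) from compound 1 to compound 2 and a 1.4-fold lower number (0.13 log units; within the scatter) from compound 3 to compound 4, at least 19-fold (1.28 log units) apart, beyond the scatter of two such steps

Going by these compounds, the value of compound 2, > 50000 nM, is a limit and not a number, so the true size of the first step is unknown. The comparison shows that this change cannot be assumed to act alike on both cores, but not why it differs, since the cores differ in two places: the changed group sits meta to a 4-hydroxyphenyl group in compound 1 and meta to a 3-hydroxyphenyl group in compound 3, and the fluorinated aryl groups differ too.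

The aryl swap alone gives a 1.1-fold lower number from compound 1 to compound 4 (0.04 log units; within the scatter), which leaves open whether the second hydroxyphenyl group is what matters. Also open, on these data alone, is whether the pattern would hold with an amine or a carboxylic acid in place of the hydroxyl.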